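The source may report more compounds than this note shows. Statements on the series, on what has been measured and on what is new or still open speak of the compounds shown alone.

For the measured compounds named here, in an assay on isolated protein (Bos taurus) for inhibition of tissue alpha-L-fucosidase (Homo sapiens) (on this read-out lower numbers stand for stronger inhibition and higher numbers for weaker inhibition), compound 1 `CCNC1CC(C)C(O)C(O)C1O` gives 21000 nM, and compound 2 `CCCCNC1CC(C)C(O)C(O)C1O` gives 920 nM, the lowest of the two numbers so far. Compound 3 `CCCCCCCNC1CC(C)C(O)C(O)C1O` differs from compound 2 by propyl in place of hydrogen on a saturated chain carbon, four bonds along the chain from an amine nitrogen, so the same chain grows once more. Going by the values given here, the one measured step that bears on this change is a 23-fold lower number from compound 1 to compound 2 (1.36 log units; beyond the scatter), a large one; a further drop in this assay is therefore expected, though probably a smaller one. Compound 3 is expected to give about 200 nM, within a range of 50 nM to 900 nM. For compound 3 the expected step is a 4.6-fold lower number from compound 2 to compound 3 (0.66 log units; beyond the scatter).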

Compound 3, half-maximal inhibitory concentration: 270 nM
For compound 3 the middle estimate is 1.4-fold (0.13 log units) below the measured one; low and high end bracket the measured number.
By their numbers in this assay, from the lowest: compound 3; then compound 2; then compound 1.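

In this assay, the number keeps falling when propyl enters four bonds along the chain from an amine nitrogen, with a 3.4-fold lower number from compound 2 to compound 3 (0.53 log units; beyond the scatter) as a modest step. So the chain can grow further without losing strength, though this step is smaller than the large one before it (a 23-fold lower number from compound 1 to compound 2 (1.36 log units; beyond the scatter)). Across all three compounds, the total change is a 78-fold lower number from compound 1 to compound 3 (1.89 log units; beyond the scatter) and runs in one direction. No measurement here explains why the number falls. On these data alone, whether a longer chain would lower the number further or raise it stays open. So does whether a chain ending in a phenyl ring or a hydroxyl group would behave like this one.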